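A few compounds are considered here, and "the series" means these few. Any claim that something is new, unique, unknown or untested is made for them only; others in the source may bear on it.

Working notes on the series.

Three compounds on the shared core of compound 1 `CS(=O)(=O)Nc1ccc(CNC(=O)c2ccc(C3(C(F)(F)F)CC3)cc2)c(Cl)c1` have been measured in an assay on HeLa cells for agonist activity at Bile acid receptor (Homo sapiens), read by a luciferase reporter, with a stated time of 24 h; on this read-out lower numbers stand for an effect already at smaller amounts and higher numbers for an effect only at larger amounts of compound. Compound 1 gives 540 nM, the lowest number of the three. Compound 2 `CS(=O)(=O)Nc1ccc(CNC(=O)c2ccc(N3CCC3)cc2)c(Cl)c1` gives 13000 nM, and compound 3 `CS(=O)(=O)Nc1ccc(CNC(=O)c2ccc(CC(F)(F)F)cc2)c(Cl)c1` gives 4000 nM. Both changes away from the 1-(trifluoromethyl)cyclopropyl group of compound 1 raise the number: a 24-fold higher number from compound 1 to compound 2 (1.38 log units; beyond the scatter), and a 7.4-fold higher number from compound 1 to compound 3 (0.87 log units; beyond the scatter). Between the two replacements, a 3.3-fold lower number from compound 2 to compound 3 (0.51 log units; beyond the scatter).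

Compound 4 `CS(=O)(=O)Nc1ccc(CNC(=O)c2ccc(C(F)(F)C(F)(F)F)cc2)c(Cl)c1` is the next member, not yet measured in this assay. Its difference from compound 1: 1,1,2,2,2-pentafluoroethyl in place of 1-(trifluoromethyl)cyclopropyl on an aromatic carbon. The group that leaves and the group that enters each count the same number of heavy atoms, and the new group keeps the fluorine-rich character of the old one. The closest measured precedent is the step to compound 3, where a fluorinated chain also replaced the ring and the number rose modestly; the step to compound 2 is a larger departure and less instructive here. The expectation for this assay is therefore a modest rise in the number from compound 1 to compound 4, smaller than the step to compound 3, as given by a 2.4-fold higher number from compound 1 to compound 4 (0.38 log units; beyond the scatter). Compound 4 is estimated at 1300 nM, within the range 450 nM to 4000 nM.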

Compound 4, half-maximal effective concentration: 3220 nM
Estimate against measurement, compound 4: 2.5-fold (0.39 log units) below; the range from low to high includes it.
By their numbers in this assay, from the lowest: compound 1; then compounds 4 and 3 (each within the scatter of the next); then compound 2.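

In this assay, replacing the ring of compound 1 with the open 1,1,2,2,2-pentafluoroethyl group raises the number (a 6.0-fold higher number from compound 1 to compound 4 (0.78 log units; beyond the scatter)), even though the heavy-atom count stays the same and the fluorine count goes up, so neither count alone is enough to keep compound 1's value at this position on the aromatic carbon para to a large group. The two fluorinated chains cannot be told apart (a 1.2-fold lower number from compound 3 to compound 4 (0.09 log units; within the scatter), within the scatter), so the extra fluorine of the pentafluoroethyl group brings no readable change from the 2,2,2-trifluoroethyl group, while compound 4 still stands clear of the azetidine of compound 2 (a 4.0-fold lower number from compound 2 to compound 4 (0.61 log units; beyond the scatter)). No measurement at hand bears on the reason for these differences.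

As far as these compounds go, whether the ring or the fully substituted carbon matters more remains open: an unsubstituted cyclopropyl, a tert-butyl or a 1-(trifluoromethyl)cyclobutyl group at this place would help separate them. Also open, from the compounds shown here alone, is whether the same ranking would hold with a different group in place of the methanesulfonamide or the chlorine of the shared core.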